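The source may report more compounds than this note shows. Statements on the series, on what has been measured and on what is new or still open speak of the compounds shown alone.

In a functional assay on HL-60 cells (Homo sapiens) for inhibition, read by MTT assay, with a stated time of 48 h (on this read-out lower numbers stand for stronger inhibition and higher numbers for weaker inhibition), compound 1 `C=C1CN(C)N(c2ccc(Cl)cc2)C1=O` gives 38100 nM. Compound 2 `C=C1C(=O)N(c2ccccc2)N(C)C1c1ccccc1` gives 40900 nM. Compound 3 `C=C1CN(C)N(c2ccc(C)cc2)C1=O` gives 65700 nM, the highest of the three numbers shown, though it sits within the scatter of both other compounds. Among the measured compounds shown here, the only measured step touching this position, a 1.7-fold higher number from compound 1 to compound 3 (0.24 log units; within the scatter), was within the scatter. Compound 4 `C=C1CN(C)N(c2ccccc2)C1=O` differs from compound 3 by hydrogen in place of methyl on an aromatic carbon. For the measured compounds named here, no measured pair shows methyl replaced by hydrogen on the aromatic ring, so the expectation rests on the small spread among the three measured compounds. A step of a 1.3-fold lower number from compound 3 to compound 4 (0.12 log units; within the scatter) is therefore expected, meaning none beyond the scatter. Compound 4 is estimated at 50000 nM in this assay, with a range from 20000 nM to 120000 nM.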

Compound 4, half-maximal inhibitory concentration: 45700 nM
Beside the measured number, compound 4's estimate is 1.1-fold (0.04 log units) above it; measured number inside the range.
By their numbers in this assay, from the lowest: compounds 1, 2, 4 and 3 (each within the scatter of the next).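

In this assay, the ring without a substituent gives a hydrogen reference for this position: hydrogen in place of methyl gives a 1.4-fold lower number from compound 3 to compound 4 (0.16 log units; within the scatter), and hydrogen in place of chloro gives a 1.2-fold higher number from compound 1 to compound 4 (0.08 log units; within the scatter). Hydrogen in place of phenyl on a saturated ring carbon gives a 1.1-fold higher number from compound 2 to compound 4 (0.05 log units; within the scatter), so none of these changes separates from the scatter. No evidence is available to explain this result. As far as these compounds go, whether an amine or a carboxylic acid on the aromatic carbon would give a step beyond the scatter remains open.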